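The compounds below may be only part of what the source reports. "The series", "measured", "known", "first", "only" and "open" are said of these compounds alone.

Measured so far:
- compound 1 `COc1cc(C(c2ccc(O)c(OC)c2)[C@@H](C)[C@@H](C)CO)ccc1O`: > 100000 nM
- compound 2 `COc1cc(C(c2ccc(O)c(OC)c2)[C@@H](CO)C(C)C)ccc1O`: > 100000 nM
- compound 3 `COc1cc(C(c2ccc(O)c(OC)c2)[C@H](CC(C)C)C(C)C)ccc1O`: 8200 nM

In a functional assay on HeLa cells (Homo sapiens) for cytotoxicity, read by WST assay, with a stated time of 48 h (on this read-out lower numbers stand for stronger inhibition and higher numbers for weaker inhibition), compound 1 gives only a limit, not a number. Compound 2 likewise reaches only a limit. Compound 3 alone gives a measured number. Compound 1 therefore stands at the limit of > 100000 nM in this assay, at which 2 of the 3 values shown sit.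

Compound 4 `COC[C@@H](C)[C@H](C)C(c1ccc(O)c(OC)c1)c1ccc(O)c(OC)c1` differs from compound 1 in one place: 1-(methoxymethyl)ethyl in place of 1-(hydroxymethyl)ethyl on a saturated chain carbon bound to two saturated chain carbons. The step that the two limits leave unreadable from compound 1 to compound 2 gives no guidance. The steps of an at least 12-fold lower number from compound 1 to compound 3 (1.08 log units; beyond the scatter) and an at least 12-fold lower number from compound 2 to compound 3 (1.08 log units; beyond the scatter) show that removing the hydroxymethyl and enlarging the chain brings a large drop, but the change to compound 4 is smaller, keeping the oxygen. A modest drop is therefore expected, an at least 1.6-fold lower number from compound 1 to compound 4 (0.22 log units; that floor lies within the scatter), though compound 4 may again sit at the limit. Compound 4 is estimated at 60000 nM, between 15000 nM and 200000 nM.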

Compound 4, half-maximal inhibitory concentration: 58000 nM
Estimate against measurement, compound 4: 1.0-fold (0.01 log units) above; low and high end bracket the measured number.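

In this assay the change from 1-(hydroxymethyl)ethyl to 1-(methoxymethyl)ethyl, which removes that group's hydrogen-bond donor, gives an at least 1.7-fold lower number from compound 1 to compound 4 (0.23 log units; that floor lies within the scatter) and also yields an at least 1.7-fold lower number from compound 2 to compound 4 (0.23 log units; that floor lies within the scatter) while replacing a limit with a measured number. Going by these compounds, both steps are only floors, so the true size of the change stays unknown. The 2-(methoxymethyl)-1-methylpropyl chain still falls short of 1-isopropyl-3-methylbutyl, with a 7.1-fold higher number from compound 3 to compound 4 (0.85 log units; beyond the scatter) on the same saturated chain carbon bound to two aromatic carbons. On these data alone, what an amine, a carboxylic acid or a longer ether chain would do at this place stays open.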